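Working notes: tolerated concentration across three analogues

The source may report more compounds than this note shows. Statements on the series, on what has been measured and on what is new or still open speak of the compounds shown alone.

Among the compounds with values here, compound 2 `Nc1nc(SCc2ccccc2)c2ncn(/C=C3/CC3(CO)CO)c2n1` is one of two members measured so far in an ADME assay on BCBL1 cells (Homo sapiens) for cytotoxicity, with a stated time of 7 days; a higher number here means that more compound is tolerated, a lower number that less compound is tolerated. In this assay compound 2 gives > 20000 nM, which is a limit of the assay rather than a number. Its neighbour compound 1 `CCCCCCCCOc1nc(N)nc2c1ncn2/C=C1/CC1(CO)CO` differs from it at one place, benzylsulfanyl in place of octyloxy on an aromatic carbon. In this assay compound 1 gives > 20000 nM, again a limit. The step that the two limits leave unreadable from compound 1 to compound 2 is thus of unknown size; what is known is the limit of > 20000 nM in this assay, at which 2 of the 2 values shown sit. Compound 3 `CNc1nc(N)nc2c1ncn2/C=C1/CC1(CO)CO` is the next analogue, reached from compound 2 by methylamino in place of benzylsulfanyl on an aromatic carbon. Within the data shown here, the single measured step bears on it only by showing that two quite different groups at this carbon both left the compound tolerated up to the limit; no sized step exists to carry over. The step from compound 2 to compound 3 is expected to be a step that the limit leaves unreadable from compound 2 to compound 3, most likely ending again at the assay limit. For compound 3 the estimate in this assay is 30000 nM, with a range from 15000 nM to 80000 nM.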

Compound 3, half-maximal cytotoxic concentration: 67000 nM
Beside the measured number, compound 3's estimate is 2.2-fold (0.35 log units) below it, and the stated range covers the measured number.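

The steps to compound 3 from compound 1 and compound 2 cannot be read in this assay, because both of those compounds stand at a limit of the assay rather than a number: the limit of > 20000 nM in this assay, at which 2 of the 3 values shown sit.

Left open is whether octyloxy, benzylsulfanyl and methylamino differ at all in tolerated concentration.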